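Adding a Methylsulfanyl Group to the Core of Compound 3

A few compounds are considered here, and "the series" means these few. Any claim that something is new, unique, unknown or untested is made for them only; others in the source may bear on it.

Compound 1, `FC(F)(F)c1ccc(Nc2ncnc3sc(Nc4c(Cl)cccc4Cl)nc23)cc1`, gives 3 nM in a functional assay on HEK293 cells for antagonist activity at transient receptor potential cation channel subfamily V member 1 (Rattus norvegicus), read by calcium flux; on this read-out higher numbers stand for weaker inhibition and lower numbers for stronger inhibition.
Compound 2, `O=S(=O)(c1ccc(Nc2ncnc3sc(Nc4c(Cl)cccc4Cl)nc23)cc1)N1CCCC1`, gives 0.5 nM in this assay.
Compound 3, `FC(F)(F)c1ccc(Nc2ncnc3sc(Nc4c(Cl)cccc4Cl)nc23)cc1Cl`, gives 9 nM in this assay.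

Among these three, compound 3 carries the highest number, meaning the weakest inhibition. Its closest neighbour is compound 1, and the step between them is a 3.0-fold higher number from compound 1 to compound 3 (0.48 log units; beyond the scatter). Compound 2 stands furthest below it; no single-point comparison between compound 3 and compound 2 is available, so only their two values speak.

Compound 4, `CSc1nc(Nc2ccc(C(F)(F)F)c(Cl)c2)c2nc(Nc3c(Cl)cccc3Cl)sc2n1`, differs from compound 3 in one place: methylsulfanyl in place of hydrogen on an aromatic carbon. Both measured steps, a 6.0-fold lower number from compound 1 to compound 2 (0.78 log units; beyond the scatter) and a 3.0-fold higher number from compound 1 to compound 3 (0.48 log units; beyond the scatter), concern the aromatic ring bearing the trifluoromethyl group, not the shared core between the two ring nitrogens. Within the data shown here, no measured step therefore bears on this change, and the direction of any effect is open.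

In this assay compound 4 is expected to sit close to compound 3, with an estimated step of a 1.1-fold higher number from compound 3 to compound 4 (0.05 log units; within the scatter), which is within the usual scatter. The estimate for compound 4 is 10 nM, with a range from 2.5 nM to 40 nM reflecting the absence of guiding data.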

Compound 4, half-maximal inhibitory concentration: 113 nM
For compound 4 the middle estimate is 11-fold (1.05 log units) below the measured one; measured number above the stated range.
By their numbers in this assay, from the lowest: compound 2; then compound 1; then compound 3; then compound 4.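

Compounds 1, 2 and 3 differ only on the ring bearing the trifluoromethyl group, so they say nothing about the shared core; here, on the aromatic carbon between two ring nitrogen atoms, the core proves sensitive to substitution. In this assay, methylsulfanyl in place of hydrogen gives a 13-fold higher number from compound 3 to compound 4 (1.10 log units; beyond the scatter), a step larger in size than either a 6.0-fold lower number from compound 1 to compound 2 (0.78 log units; beyond the scatter) or a 3.0-fold higher number from compound 1 to compound 3 (0.48 log units; beyond the scatter), so inhibition weakens clearly even though the entering group adds only 2 heavy atoms, no ring and no net charge. Nothing available explains why this position responds so strongly.

A single substituent cannot show whether any group on this carbon weakens inhibition or whether the loss is particular to methylsulfanyl; an amine, a methoxy group or a longer chain such as ethylsulfanyl at the same place would help to separate these possibilities. Going by these compounds, it also remains open whether the same change would cost as much on the ring pattern of compound 1 or compound 2 as it does on that of compound 3.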